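The source may report more compounds than this note shows. Statements on the series, on what has been measured and on what is new or still open speak of the compounds shown alone.

Among the measured compounds shown here, compound 2 `C[C@H](Nc1c(NCCCCCC(=O)NO)c(=O)c1=O)c1ccccc1` is one of the two measured members. In an ADME assay on cells (Hepatocyte, Homo sapiens) for pharmacokinetics, read by LC-MS, with a stated time of 90 min, tested at 1 uM (a higher number here means faster removal of the compound, a lower number slower removal), compound 2 gives < 5 uL/min, which is a limit of the assay and not a number. Compound 1 `O=C(CCCCCNc1c(NCc2ccccc2)c(=O)c1=O)NO` carries the shared core without the branch. In this assay compound 1 gives < 4.8 uL/min, again a limit. For the measured compounds named here, the only measured step is a step that the two limits leave unreadable from compound 1 to compound 2; with both values sitting at limits, the limit of < 4.8 uL/min in this assay, at which 1 of the 2 values shown sits, and (the limit of < 5 uL/min in this assay, at which 1 of the 2 values shown sits), its size cannot be read. Compound 3 `CC[C@H](Nc1c(NCCCCCC(=O)NO)c(=O)c1=O)c1ccccc1` has not been measured in this assay. It differs from compound 2 by methyl in place of hydrogen on a saturated chain carbon, two bonds along the chain from an aromatic carbon and a nitrogen on an aromatic ring. No measured step bears on this change, and the single step shown is itself unreadable, so no direction can be expected beyond the scatter; the likeliest outcome is another value at the limit. Compound 3 is expected to sit at 4 uL/min, in the range 2 uL/min to 10 uL/min. This expectation means a step that the limit leaves unreadable from compound 2 to compound 3, expected to lie within the scatter.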

Compound 3, intrinsic clearance in a liver preparation (reported as CLH), per the amount of preparation that the assay uses: < 5 uL/min
Compound 3: no number, only a limit; the forecaster's own chance of this, stated with the estimate: 65%; the middle value does not contradict the limit.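

The steps among compound 1, compound 2 and compound 3 cannot be read, as all three values are limits of the assay and not numbers: the limit of < 5 uL/min in this assay, at which 2 of the 3 values shown sit.

Left open are the actual intrinsic clearance of each compound and whether methyl or ethyl in place of hydrogen changes it at all in this assay.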